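The compounds below may be only part of what the source reports. "The series", "measured", "known", "first", "only" and "open" are said of these compounds alone.

Measured compounds in an ADME assay on microsomes from liver (Homo sapiens) for metabolic stability; a lower number here means that the compound disappears faster, a higher number that the compound lasts longer:

- compound 1, `COc1ccc(OC)c(-c2cc(C3=Nc4c(C(C)(C)C)nn(CCCO)c4C(=O)NC3)ccc2OC)c1`, 1.02 h
- compound 2, `COc1ccc(C2=Nc3c(C(C)(C)C)nn(CCCO)c3C(=O)NC2)cc1-c1cnn(C)c1`, 2 h
- compound 3, `COc1ccc(-c2cc(C3=Nc4c(C(C)(C)C)nn(CCCO)c4C(=O)NC3)ccc2OC)c(OC)c1`, 2 h

Compound 3 stands level with compound 2 at the digits shown, and the two share the highest number of the three; the step of a 2.0-fold higher number from compound 1 to compound 3 (0.29 log units; within the scatter) and the step of no change at the digits printed from compound 2 to compound 3 (within the scatter) are both within the scatter, so no ordering among the three can be claimed.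

Compound 4, `COc1ccc(C2=Nc3c(C(C)(C)C)nn(CCCO)c3C(=O)NC2)cc1-c1ccccc1F`, differs from compound 3 by 2-fluorophenyl in place of 2,4-dimethoxyphenyl on an aromatic carbon. Going by the values given here, none of the measured steps replaces this group by a phenyl carrying a single fluorine, so none bears on it directly; what the measured steps do show is that exchanging one aryl substituent for another at this same position, as in a 2.0-fold higher number from compound 1 to compound 2 (0.29 log units; within the scatter), a 2.0-fold higher number from compound 1 to compound 3 (0.29 log units; within the scatter) and no change at the digits printed from compound 2 to compound 3 (within the scatter), left this assay within the scatter each time. On that basis compound 4 is expected to stay close to compound 3, with the step of no change at the digits printed from compound 3 to compound 4 (within the scatter) estimated to lie within the scatter. Compound 4 is therefore estimated at 2 h, with a range from 1 h to 4 h.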

Compound 4, half-life: 0.8 h
Compound 4: middle estimate off by 2.5-fold (0.40 log units), on the high side; the whole stated range lies above it.
By their numbers in this assay, from the lowest: compounds 4, 1, 2 and 3 (each within the scatter of the next, the first and the last beyond it).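

In this assay, going by these compounds alone, this position proves sensitive to the choice of ring after all: a 2.5-fold lower number from compound 3 to compound 4 (0.40 log units; beyond the scatter) and a 2.5-fold lower number from compound 2 to compound 4 (0.40 log units; beyond the scatter) are the first steps in this set to pass beyond the scatter, although both are modest. So 2-fluorophenyl separates from both 2,4-dimethoxyphenyl and 1-methyl-1H-pyrazol-4-yl, showing that exchanging one ring for another here is not always neutral. It does not separate from every group, however, as a 1.3-fold lower number from compound 1 to compound 4 (0.11 log units; within the scatter) leaves 2-fluorophenyl and 2,5-dimethoxyphenyl indistinguishable.

Nothing shown here gives a reason for these differences. On these data alone, it remains open whether the fluorine or the missing methoxy groups matter more, which a plain phenyl or a phenyl carrying a single methoxy group could test, and how a ring bearing an amine or a carboxylic acid would behave at this position.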